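This account rests on a few compounds, and the source may have more. Where it says the series, first, only, none or still open, it means among the compounds named here.

Among the compounds with values here, compound 2, `COc1cc(-c2ccnc3cc(-c4cn(C)c5ccccc45)nn23)cc(OC)c1OC`, is one of two compounds measured in a functional assay on HCT-116 cells (Homo sapiens) for inhibition, read by CCK-8 assay, with a stated time of 48 h; on this read-out lower numbers stand for stronger inhibition and higher numbers for weaker inhibition. In this assay compound 2 gives 762 nM. Within the data shown here, its only neighbour is compound 1, `COc1cc(-c2ccnc3cc(-c4ccc5ccn(C)c5c4)nn23)cc(OC)c1OC`, which in this assay gives 1040 nM; the two differ at one place, and the step is a 1.4-fold lower number from compound 1 to compound 2 (0.14 log units; within the scatter), so the two values cannot be told apart. Compound 2 therefore holds the lower of the two numbers shown, but without a difference that the scatter would allow to be called real.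

Compound 3, `C=Cc1ccc(-c2cc3nccc(-c4cc(OC)c(OC)c(OC)c4)n3n2)cc1`, has not yet been measured in this assay. It differs from compound 2 as follows: 4-vinylphenyl in place of 1-methyl-1H-indol-3-yl on an aromatic carbon. Among the measured compounds shown here, no measured step bears directly on this change; the single step available, from compound 1 to compound 2, exchanges one indolyl for another and stays within the scatter, whereas here the indolyl leaves altogether. For the measured compounds named here, with no comparable precedent, the expectation rests on the size of the change alone, and a modest shift toward a higher number is expected, a 2.0-fold higher number from compound 2 to compound 3 (0.29 log units; within the scatter), with a wide range. For compound 3 in this assay a value of 1500 nM is estimated, between 400 nM and 6000 nM.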

Compound 3, half-maximal inhibitory concentration: 1060 nM
Beside the measured number, compound 3's estimate is 1.4-fold (0.15 log units) above it, within the range that was stated.
By their numbers in this assay, from the lowest: compounds 2, 1 and 3 (each within the scatter of the next).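

In this assay, the earlier pair had only exchanged one indolyl for another, whereas compound 3 removes the indolyl altogether from this aromatic carbon of the five-membered aromatic ring with 2 nitrogen, and the result is a 1.4-fold higher number from compound 2 to compound 3 (0.14 log units; within the scatter). Measured against the other indolyl, the same replacement gives a 1.0-fold higher number from compound 1 to compound 3 (0.01 log units; within the scatter), so in both comparisons a 4-vinylphenyl, with its single six-membered aromatic ring of carbon only, its double bond outside the ring and no hydrogen-bond acceptor, cannot be told apart from the indolyl it replaces. Nothing available explains why the number holds through this change of group.

All three compounds lie within the scatter of one another, so the compounds shown do not reveal any group at this position that moves the number by a real margin. As far as these compounds go, it remains open whether an amine, a carboxylic acid or a longer chain in place of the 4-vinylphenyl would do so, and what a change elsewhere in the core, which is the same in all three compounds, would bring.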